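The source may report more compounds than this note shows. Statements on the series, on what has been measured and on what is new or still open speak of the compounds shown alone.

Compound 1 `CSc1nc(=O)ccn1[C@@H]1O[C@H](COP(=O)(O)OP(=O)(O)O)[C@@H](O)[C@H]1O` carries a methylsulfanyl group on the shared core and a diphosphate chain. Within the data shown here, in an in vitro functional assay on 1321-N1 cells for agonist activity at P2Y purinoceptor 6 (Homo sapiens), read by scintillation proximity assay and inositol phosphate accumulation (on this read-out higher numbers stand for an effect only at larger amounts of compound and lower numbers for an effect already at smaller amounts), compound 1 gives 4700 nM, which is the only proper number among the three measured values. Compound 3 `CSc1nc(=O)ccn1[C@@H]1O[C@H](COP(=O)(O)O)[C@@H](O)[C@H]1O` keeps the methylsulfanyl group but has a single phosphate in place of the diphosphate; in this assay compound 3 reaches only the limit > 100000 nM. Compound 2 `CNc1nc(=O)ccn1[C@@H]1O[C@H](COP(=O)(O)O)[C@@H](O)[C@H]1O` has methylamino in place of methylsulfanyl, again with the single phosphate; in this assay compound 2 likewise stops at the limit > 100000 nM. The step from compound 1 to compound 3 shows an at least 21-fold higher number from compound 1 to compound 3 (1.32 log units; beyond the scatter), so removing the terminal phosphate costs a great deal. The step from compound 2 to compound 3 is a step that the two limits leave unreadable from compound 2 to compound 3 because both values sit at the limit of > 100000 nM in this assay, at which 2 of the 3 values shown sit.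

Compound 4 `O=c1ccn([C@@H]2O[C@H](COP(=O)(O)OP(=O)(O)O)[C@@H](O)[C@H]2O)c(SCc2ccccc2)n1` differs from compound 1 by phenyl in place of hydrogen on a saturated chain carbon bound to a sulfur; the diphosphate remains in place. Neither measured step touches this part of the molecule: one removes a phosphate, the other swaps methylamino for methylsulfanyl and cannot be read. With the diphosphate kept, compound 4 is expected to stay active, and with no evidence on enlarging the sulfanyl group the expected step is a 1.5-fold higher number from compound 1 to compound 4 (0.17 log units; within the scatter), within the scatter. Compound 4 is therefore estimated at 7000 nM, within a range from 1500 nM to 40000 nM.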

Compound 4, half-maximal effective concentration: 6800 nM
Compound 4: the middle estimate sits 1.0-fold (0.01 log units) above what was measured; the measured number falls inside the stated range.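

Among these compounds, until this result, the only comparison on this side of the core was methylsulfanyl against methylamino, and it could not be read, so nothing was known about changing the group on the sulfur. Replacing a hydrogen of methylsulfanyl with phenyl, which turns it into benzylsulfanyl, gives a 1.4-fold higher number from compound 1 to compound 4 (0.16 log units; within the scatter) in this assay, so with the diphosphate chain in place, this position accepts a whole six-membered aromatic ring with no change in the read-out beyond the usual scatter. The data shown give no reason for this lack of change, and what they do show concerns only this one pair of compounds carrying the diphosphate chain.

On these data alone, it remains open whether a longer chain such as phenylethylsulfanyl, or an amine or a carboxylic acid placed on the phenyl ring, would move the number in either direction, which would show whether this position can do more than accept added bulk. As far as these compounds go, it is also open whether benzylsulfanyl would give a readable number on a compound with a single phosphate in place of the diphosphate.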